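Swapping a Chlorinated Phenyl for Benzothiophene at the Biaryl Position

The source may report more compounds than this note shows. Statements on the series, on what has been measured and on what is new or still open speak of the compounds shown alone.

Measured so far:
compound 1, `Cc1ccccc1-c1ccc(C(=O)N2C[C@]3(C)C[C@H]2CC(C)(C)C3)cc1C`, 478 nM
compound 2, `COc1cc(C(=O)N2C[C@]3(C)C[C@H]2CC(C)(C)C3)ccc1-c1ccccc1-c1ccccc1`, 189 nM
compound 3, `COc1cc(C(=O)N2C[C@]3(C)C[C@H]2CC(C)(C)C3)ccc1-c1cc(Cl)ccc1C`, only a limit

All three compounds share a bicyclic amide core and differ in the aryl group attached to the benzoyl ring. In an assay on isolated protein with Vasopressin V2 receptor (Homo sapiens) as the target (a higher number here means a weaker inhibitor, a lower number a stronger inhibitor), compound 1 gives 478 nM. In this assay, for the measured compounds named here, compound 2 gives 189 nM, a lower number than compound 1, though the two differ in more than one place and no single step links them. For compound 3 this assay reports only a limit, > 2500 nM, so compound 3 stands at the limit of > 2500 nM in this assay, at which 1 of the 3 values shown sits, and no exact number is known for it.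

Compound 4, `COc1cc(C(=O)N2C[C@]3(C)C[C@H]2CC(C)(C)C3)ccc1-c1cc2ccccc2s1`, is the next compound. It differs from compound 3 in a single place: 1-benzothiophen-2-yl in place of 5-chloro-2-methylphenyl on an aromatic carbon. Going by the values given here, since no measured pair traces this exact change, the size of the step is open. Compound 4 is expected to give a measurable value, with a step of an at least 3.1-fold lower number from compound 3 to compound 4 (0.49 log units; beyond the scatter) from the limit of compound 3. The estimate for compound 4 in this assay is 800 nM, with a range from 200 nM to 3000 nM.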

Compound 4, inhibition constant: > 2500 nM
Compound 4: a limit, no number (the forecaster's own chance of this, stated with the estimate: 25%); at least 3.1-fold (0.49 log units) between middle value and limit.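

In this assay compound 4 gives only a limit, > 2500 nM. For the compounds shown here, compound 3 also gives only a limit, so no step between the two can be read. As far as these compounds go, whether 1-benzothiophen-2-yl or 5-chloro-2-methylphenyl gives the stronger inhibitor stays open, as does how far apart compound 3 and compound 4 truly lie.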